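This account rests on a few compounds, and the source may have more. Where it says the series, first, only, none or still open, it means among the compounds named here.

Within the data shown here, the two compounds measured so far both give high numbers in a functional assay on SK-OV-3 cells (Homo sapiens) for antiproliferative activity, read by MTT assay, with a stated time of 72 h; on this read-out lower numbers stand for stronger inhibition and higher numbers for weaker inhibition. Compound 1 (`COc1cc(OC)cc(-c2cccc(NC(=O)CCc3ccc4c(c3)COB4O)c2)c1`) gives 93000 nM, and compound 2 (`O=C(CCc1cccc2c1C(O)OC2)Nc1ccccc1`) gives 78000 nM. These two numbers lie within the usual scatter of repeated measurements, so compound 2 stands level with compound 1 and neither can be ranked over the other. The next compound, compound 3 (`COc1cccc(-c2cccc(NC(=O)CCc3cccc4c3C(O)OC4)c2)c1`), comes from compound 2 by a single change: 3-methoxyphenyl in place of hydrogen on an aromatic carbon, meta to a large group (3-methoxyphenyl in place of hydrogen on an aromatic carbon). Among the measured compounds shown here, no measured pair shows what such a change does in this assay, so any forecast rests on thin ground. Compound 1 at 93000 nM and compound 2 at 78000 nM mark the only range seen so far, and nothing measured points far outside it. The expected change is therefore none beyond the scatter, with a slight lean toward lower numbers, and the estimated step is a 1.6-fold lower number from compound 2 to compound 3 (0.19 log units; within the scatter). For compound 3 the expected value is 50000 nM, with an estimated range from 15000 nM to 120000 nM.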

Compound 3, half-maximal inhibitory concentration: 61000 nM
For compound 3 the middle estimate is 1.2-fold (0.09 log units) below the measured one; the measured number falls inside the stated range.
By their numbers in this assay, from the lowest: compounds 3, 2 and 1 (each within the scatter of the next).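

In this assay, putting 3-methoxyphenyl in place of hydrogen on an aromatic carbon, meta to a large group, gives a 1.3-fold lower number from compound 2 to compound 3 (0.11 log units; within the scatter), so compound 3 stands level with compound 2. Among these compounds, this is the first measured step at this position, and it shows that an added group of this size, carrying a whole aromatic ring and one hydrogen-bond acceptor, leaves the number within what repeat measurements alone could produce: the change neither brings clear gain nor clear loss in this read-out. Nothing at hand explains this outcome.

On these data alone, a single substituent at a single position says little about the position as a whole, so it remains open whether a different group placed there, such as an amine, a carboxylic acid or a plain methyl, would move the number beyond the scatter. As far as these compounds go, it also remains open whether changes elsewhere on compound 3, for instance a longer chain in place of the one carrying the amide, would shift the number away from the high range seen so far.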